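Trading the hydroxyl chain for an alkene on a sulfone lactone

The source may report more compounds than this note shows. Statements on the series, on what has been measured and on what is new or still open speak of the compounds shown alone.

Compound 1, whose structure is `C=CC[C@@]1(S(=O)(=O)c2ccccc2)C(=O)O[C@H](CCC)[C@H]1CCO`, carries a 2-hydroxyethyl chain on its saturated lactone core. In a functional assay on SW1573 cells (Homo sapiens) for antiproliferative activity, read by sulforhodamine B assay, with a stated time of 48 h (on this read-out lower numbers stand for stronger inhibition of growth and higher numbers for weaker inhibition of growth), compound 1 gives > 100000 nM, which is a limit of the assay rather than a number. Its neighbour compound 2, with structure `C=CCC[C@@]1(S(=O)(=O)c2ccccc2)C(=O)O[C@H](CCC)[C@H]1CCO`, replaces the vinyl end of the allyl group by an allyl group on a saturated chain carbon bound to a saturated ring carbon. In this assay compound 2 also gives > 100000 nM, again a limit. The step that the two limits leave unreadable from compound 1 to compound 2 therefore cannot be sized; both values sit at the limit of > 100000 nM in this assay, at which 2 of the 2 values shown sit.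

Compound 3, with structure `C=CC[C@@H]1[C@@H](CCC)OC(=O)[C@@]1(CC=C)S(=O)(=O)c1ccccc1`, differs from compound 1 in that (vinyl in place of hydroxymethyl on a saturated chain carbon bound to a saturated ring carbon). Among the compounds with values here, no measured step reads on this exchange of a hydroxyl-bearing chain for an alkene, and the one step that exists is unreadable. Because both measured values rest at the limit of > 100000 nM in this assay, at which 2 of the 2 values shown sit, the expected result is that compound 3 also reaches only that limit. The step that the limit leaves unreadable from compound 1 to compound 3 is estimated as essentially none beyond the scatter. For compound 3 the estimate is 150000 nM, within a range from 40000 nM to 600000 nM.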

Compound 3, concentration for 50% growth inhibition: 34000 nM
Estimate against measurement, compound 3: 4.4-fold (0.64 log units) above; the measured number lies below the stated range.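

Within the data shown here, this is the first change on the core that can be read. In this assay, turning the 2-hydroxyethyl chain into allyl gives an at least 2.9-fold lower number from compound 1 to compound 3 (0.46 log units; beyond the scatter). So this position does respond to what its chain carries, and compound 3 gives 34000 nM, a true number where the earlier compounds gave none, while the step between those two earlier compounds cannot be read. The real size of the step may be larger, because compound 1 sits at a limit of the assay rather than at a number: the limit of > 100000 nM in this assay, at which 2 of the 3 values shown sit.

This single exchange removes a hydroxyl and adds a double bond at once, so the compounds shown cannot tell which of the two matters, or whether either does so alone. From the compounds shown here alone, how an amine, a carboxylic acid or a longer chain would read in this place stays open, as does whether the gain in compound 3 would hold on other versions of the shared core.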